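Piperidine nitrogen substituent variation in a sulfonamide series

A few compounds are considered here, and "the series" means these few. Any claim that something is new, unique, unknown or untested is made for them only; others in the source may bear on it.

Among the compounds with values here, compound 3 `O=C(c1cccnc1)N1CCC(NS(=O)(=O)c2cc(S(=O)(=O)c3ccccc3)ccc2C(F)(F)F)CC1` gives 80 nM in an assay on isolated protein for displacement of a labelled ligand from secreted frizzled-related protein 1 (Homo sapiens), read by fluorescence polarization, with a stated time of 30 min (on this read-out lower numbers stand for stronger inhibition and higher numbers for weaker inhibition), the second highest of the three numbers so far: compound 1 `O=C(c1ccccc1)N1CCC(NS(=O)(=O)c2cc(S(=O)(=O)c3ccccc3)ccc2C(F)(F)F)CC1` gives 70 nM, a 1.1-fold higher number from compound 1 to compound 3 (0.06 log units; within the scatter), while compound 2 `O=C(c1ccc(Cl)cc1)N1CCC(NS(=O)(=O)c2cc(S(=O)(=O)c3ccccc3)ccc2C(F)(F)F)CC1` gives 300 nM, a 3.8-fold lower number from compound 2 to compound 3 (0.57 log units; beyond the scatter). Compound 4 `O=C(O)c1cccc(S(=O)(=O)N2CCC(NS(=O)(=O)c3cc(S(=O)(=O)c4ccccc4)ccc3C(F)(F)F)CC2)c1` carries (3-carboxyphenyl)sulfonyl in place of (pyridin-3-yl)carbonyl on an amine nitrogen in a ring. Within the data shown here, the steps bearing on this position are a 4.3-fold higher number from compound 1 to compound 2 (0.63 log units; beyond the scatter) and a 3.8-fold lower number from compound 2 to compound 3 (0.57 log units; beyond the scatter), both modest, so changes of the group on this nitrogen have shifted this assay only moderately; no measured step covers a sulfonyl or a carboxylic acid at this place. The expectation is a modest step, a 2.5-fold higher number from compound 3 to compound 4 (0.40 log units; beyond the scatter), toward a higher number. Compound 4 is therefore estimated at 200 nM, within 50 nM to 800 nM.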

Compound 4, half-maximal inhibitory concentration: 20 nM
The estimate for compound 4 lay 10-fold (1.00 log units) above the measured number, outside the stated range (below it).
By their numbers in this assay, from the lowest: compound 4; then compounds 1 and 3 (each within the scatter of the next); then compound 2.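

Working notes: the group on this amine nitrogen can also lower the number in this assay, since (3-carboxyphenyl)sulfonyl falls beyond the scatter below both earlier low values (a 4.0-fold lower number from compound 3 to compound 4 (0.60 log units; beyond the scatter)) and (a 3.5-fold lower number from compound 1 to compound 4 (0.54 log units; beyond the scatter)). Against the 4-chlorophenyl amide the change gives the first large step at this place (a 15-fold lower number from compound 2 to compound 4 (1.18 log units; beyond the scatter)). No measured evidence bears on the reason for this change in the number.

On these data alone, the sulfonyl and the carboxylic acid enter together, so their separate shares stay open. A plain phenylsulfonyl or a 3-carboxybenzoyl on this nitrogen would separate them.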